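Cytotoxicity notes on the series: compound 1 toward compound 4

A few compounds are considered here, and "the series" means these few. Any claim that something is new, unique, unknown or untested is made for them only; others in the source may bear on it.

Measured so far:
- compound 1 `CN(C)c1cc2[nH]c(C3CCCCC3)nc2cc1NC(=O)c1cccs1` gives in an ADME assay on Vero cells (Chlorocebus sabaeus) for cytotoxicity, read by resazurin assay, with a stated time of 3 days (on this read-out higher numbers stand for weaker inhibition and lower numbers for stronger inhibition), the limit > 100 ug/mL.
- compound 2 `CCCCOC(=O)Nc1cc2nc(C3CCCCC3)[nH]c2cc1N(CC)CCN(C)C` gives in this assay the limit > 100 ug/mL.
- compound 3 `CCCN(CCC)c1cc2[nH]c(C3CCCCC3)nc2cc1NC(=O)c1ccccc1` gives in this assay the limit > 100 ug/mL.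

Compound 1 therefore stands only at a limit, not at a number, and so do the other two measured compounds: the limit of > 100 ug/mL in this assay, at which 3 of the 3 values shown sit. Among the measured compounds shown here, no pair of measured compounds differs in one place, so no step size is known from the data themselves.

Compound 4 `CN(C)c1cc2[nH]c(C3CCCCC3)nc2cc1NC(=O)c1ccc(Br)cc1` is not yet measured. It differs from compound 1 by 4-bromophenyl in place of thiophen-2-yl on a carbonyl carbon.

With all three measured values sitting at the same limit, the expectation for the step of a number no higher from compound 1 to compound 4 (the limit leaves the size open) is none beyond the scatter. Compound 4 is estimated at 100 ug/mL, within 50 ug/mL to 200 ug/mL, most likely reported again as a limit.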

Compound 4, half-maximal inhibitory concentration: > 100 ug/mL
Compound 4: no number, only a limit (the forecaster's own chance of this, stated with the estimate: 85%); the middle value sits exactly at the limit.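

Compound 1 and compound 4 both stand only at a limit, so no step between them can be read: the limit of > 100 ug/mL in this assay, at which 4 of the 4 values shown sit.
The compounds shown leave open at what concentration any of them would reach half-maximal inhibition, and whether 4-bromophenyl and thiophen-2-yl differ at all.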